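This account rests on a few compounds, and the source may have more. Where it says the series, first, only, none or still open, it means among the compounds named here.

Compound 1, `Cc1ccc(/N=N/N(C)C(=O)NCCSc2ccc(O)cc2)cc1`, in a physicochemical assay for pharmacokinetics, read by HPLC, in phosphate buffer, at pH 7.4; a higher number here means that the compound lasts longer, a lower number that the compound disappears faster: > 240 h, a limit of the assay.
Compound 2, `CC(=O)c1ccc(/N=N/N(C)C(=O)NCCSc2ccc(O)cc2)cc1`, in this assay: > 240 h, a limit of the assay.
Compound 3, `CCOC(=O)c1ccc(/N=N/N(C)C(=O)CCc2ccc(O)cc2)cc1`, in this assay: 130 h.

Compound 2 stands at the upper limit of this assay, so the assay gives no number for it, only the statement that its half-life lies past what was followed. Compound 1 sits at that same limit. Going by the values given here, the only measured step here, a step that the two limits leave unreadable from compound 1 to compound 2, therefore cannot be read, and the shared core of compound 3 differs in more than one place from the others, so no second step can be drawn.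

Compound 4, `CN(/N=N/c1ccc(Br)cc1)C(=O)NCCSc1ccc(O)cc1`, differs from compound 2 by one change: bromo in place of acetyl on an aromatic carbon. Among the compounds with values here, no measured step bears on a bromo group, and the one step that touches the acetyl group is unreadable, so no size or direction can be taken from the data. Given (the limit of > 240 h in this assay, at which 2 of the 3 values shown sit), compound 4 is expected to reach that limit as well, with the step of a number no higher from compound 2 to compound 4 (the limit leaves the size open) estimated as none beyond the scatter. Compound 4 is thus estimated at 240 h, within 100 h to 600 h.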

Compound 4, half-life: > 240 h
Compound 4: only a limit was reported; the forecaster's own chance of this, stated with the estimate: 65%; the middle value lies on the limit itself.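

Compound 4 gives > 240 h in this assay, a limit and not a number. No step among compound 1, compound 2 and compound 4 can be read, because all three stand at the same limit: the limit of > 240 h in this assay, at which 3 of the 4 values shown sit.

Going by these compounds, whether methyl, acetyl or bromo on the aromatic carbon gives the longest half-life stays open.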